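A few compounds are considered here, and "the series" means these few. Any claim that something is new, unique, unknown or untested is made for them only; others in the source may bear on it.

Measured compounds in an assay on HEK293 cells for positive allosteric modulation of metabotropic glutamate receptor 3 (Rattus norvegicus), read by thallium flux, with a stated time of 2.5 min; on this read-out lower numbers stand for an effect already at smaller amounts and higher numbers for an effect only at larger amounts of compound:

Compound 1, `CCC(=O)c1ccc(OCCCCOc2cccc(C(=O)O)c2C)c(C)c1O`: compound 1 gives "not determined" (no result reported).
Compound 2, `CCCC(=O)c1ccc(OCCCCOc2ccc(F)c(C(=O)O)c2)c(C)c1O`: compound 2 gives 438 nM.
Compound 3, `CCC(=O)c1ccc(OCCCCOc2ccc(C(=O)O)cc2C)c(C)c1O`: compound 3 gives "not determined" (no result reported).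

Of these three, compound 2 is the only one with a numerical result in this assay; compound 1 and compound 3 carry no result, so nothing can be said of how they compare with it. Compound 2 therefore stands as the sole reference point.

The step goes from compound 2 to compound 4, `Cc1c(OCCCCOc2ccc(F)c(C(=O)O)c2)ccc(C(=O)CC(C)C)c1O`, which is not yet measured. The two structures differ in one place: methyl in place of hydrogen on a saturated chain carbon bound to two saturated chain carbons. The acid-bearing ring, the four-carbon linker and the hydroxylated aryl ketone core are shared; only the chain of the ketone grows.

Within the data shown here, no pair of measured compounds shows what such a change does here, so there is no measured step to lean on. Given that the change is small and lies on a saturated chain, compound 4 is expected to stay close to compound 2, with a step of a 1.0-fold higher number from compound 2 to compound 4 (0.01 log units; within the scatter) that lies within the usual scatter rather than beyond it. Compound 4 is thus estimated to give about 450 nM in this assay, with a range from 150 nM to 1300 nM.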

Compound 4, half-maximal effective concentration: 920 nM
The estimate for compound 4 lay 2.0-fold (0.31 log units) below the measured number, within the range that was stated.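

Among these compounds, the change of propylcarbonyl to isobutylcarbonyl gave in this assay a 2.1-fold higher number from compound 2 to compound 4 (0.32 log units; beyond the scatter), the first measured step. It shows that this saturated chain carbon is not indifferent to a single added methyl: the effect moved to somewhat larger amounts of compound, by a modest margin that lies beyond the usual scatter, while compound 4 still gave a numerical result. Nothing available bears on what lies behind this shift.

One step cannot show whether the number rises steadily with the size of the group on this chain, or whether other groups at the same carbon, such as a hydroxyl, an amine, a cyclopropyl ring or a longer chain such as pentyl, would move it in the same direction. As far as these compounds go, it also remains open whether methyl at this place would have the same effect with chlorine instead of fluorine on the acid-bearing ring, or with a shorter or longer linker than the four-carbon one.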